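Working notes on compound 3 and the unmeasured compound 4

The compounds below may be only part of what the source reports. "The series", "measured", "known", "first", "only" and "open" are said of these compounds alone.

Three compounds have been measured in an assay on isolated protein for inhibition of leukotriene B4 receptor 1 (Homo sapiens), tested at 10 uM; a lower number here means less inhibition, a higher number more inhibition at the concentration tested (going by the name of the read-out):
compound 1 `C=CCc1cc(C(C)=O)c(O)cc1OCCCCCC#N` gives 81%
compound 2 `C=CCc1cc(C(C)=O)c(O)cc1OCCCCCCCC#N` gives 88%
compound 3 `C=CCc1cc(C(C)=O)c(O)cc1OCCCCC` gives 60%

Compound 3 stands lowest of the three numbers. The step of a number 21 percentage points lower from compound 1 to compound 3 (beyond the scatter) and the step of a number 28 percentage points lower from compound 2 to compound 3 (beyond the scatter) both lie beyond the scatter, so compound 3 is set apart from compound 1 and from compound 2 by the loss of the group on that chain carbon. The step of a number 7 percentage points higher from compound 1 to compound 2 (within the scatter) is within the scatter.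

Compound 4 `C=CCc1cc(C(C)=O)c(O)cc1OCCCCCC` differs from compound 3 by methyl in place of hydrogen on a saturated chain carbon, five bonds along the chain from an oxygen on an aromatic ring. Within the data shown here, no measured step adds a methyl at this position; the two steps that touch this carbon, a number 21 percentage points lower from compound 1 to compound 3 (beyond the scatter) and a number 28 percentage points lower from compound 2 to compound 3 (beyond the scatter), concern the removal of a cyano-bearing group, not a lengthening of the saturated chain. The one lengthening that was measured, a number 7 percentage points higher from compound 1 to compound 2 (within the scatter), did not move the read-out beyond the scatter. On this basis the step for compound 4 in this assay is expected to be small, a number 4 percentage points higher from compound 3 to compound 4 (within the scatter), with at most a slight lean upward. Compound 4 is estimated at 64% in this assay, with a range from 48% to 80%.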

Compound 4, a percentage reported as inhibition, at one concentration (the size of the read-out at that concentration, not a potency): 50%
For compound 4 the middle estimate is 14 percentage points above the measured one; the range from low to high includes it.
By their numbers in this assay, from the lowest: compounds 4 and 3 (each within the scatter of the next); then compounds 1 and 2 (each within the scatter of the next).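

In this assay the methyl in place of hydrogen at this chain carbon gives a number 10 percentage points lower from compound 3 to compound 4 (within the scatter) and so stays inside the scatter: for the chain without a nitrile, this added carbon does not separate the two compounds. Against that flat pair, the nitrile-bearing chains stand clearly apart, with a number 31 percentage points lower from compound 1 to compound 4 (beyond the scatter) for methyl in place of cyano and a number 38 percentage points lower from compound 2 to compound 4 (beyond the scatter) for hydrogen in place of cyanomethyl, so the gap seen earlier with compound 3 is confirmed by a second compound without a nitrile, and none of the four compounds goes against this split. No data are at hand that explain this split.

Going by these compounds, whether the nitrile itself is required remains open, since a carboxylic acid, an amide or an amine at the chain end could hold the read-out equally well or lose it. Also open, on these data alone, are how a longer chain without a nitrile would read and whether the split holds as a difference in potency, since the read-out comes from a single concentration.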